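The compounds below may be only part of what the source reports. "The series", "measured", "known", "first", "only" and "open" are said of these compounds alone.

Measured compounds, read in a functional assay on Jurkat cells (Homo sapiens) for inhibition; a lower number here means a stronger inhibitor, a higher number a weaker inhibitor:
Compound 1, `CC(C)[C@H](NC(=O)COc1cccc2ccccc12)C(=O)N[C@@H](CC(=O)O)C(=O)CSc1nc(-c2ccccc2)no1`, gives 102000 nM.
Compound 2, `CC(C)[C@H](NC(=O)COc1cccc2ccccc12)C(=O)N[C@@H](CC(=O)O)C(=O)CSc1nc2ccccc2o1`, gives only a limit of the assay, > 200000 nM.
Compound 3, `CC(C)[C@H](NC(=O)COc1cccc2ccccc12)C(=O)N[C@@H](CC(=O)O)C(=O)COc1ccccn1`, gives only a limit of the assay, > 200000 nM.

Compound 3 thus stands at the limit of > 200000 nM in this assay, at which 2 of the 3 values shown sit, with no number of its own. The steps leading to it are floors only: an at least 1.9-fold higher number from compound 1 to compound 3 (0.29 log units; that floor lies within the scatter) and an at least 1.9-fold higher number from compound 1 to compound 2 (0.29 log units; that floor lies within the scatter), while a step that the two limits leave unreadable from compound 2 to compound 3 is left unreadable by the two limits. Compound 4, `CC(C)[C@H](NC(=O)COc1cccc2ccccc12)C(=O)N[C@@H](CC(=O)O)C(=O)COc1ccnc(C(F)(F)F)n1`, differs from compound 3 by 2-(trifluoromethyl)pyrimidin-4-yl in place of pyridin-2-yl on an oxygen on a saturated carbon. Going by the values given here, none of the measured steps bears on this change; all three concern the group exchanged between compounds 1, 2 and 3, not the ring on the oxygen. Among the compounds with values here, with compound 3 at the limit and no comparable step to draw on, no shift beyond the scatter can be read in either direction, and the expectation is that compound 4 in this assay again reports a limit rather than a number. Compound 4 is estimated at 250000 nM, in a range of 60000 nM to 700000 nM. The expected step is therefore a step that the limit leaves unreadable from compound 3 to compound 4.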

Compound 4, half-maximal inhibitory concentration: 37000 nM
Estimate against measurement, compound 4: 6.8-fold (0.83 log units) above; measured number below the stated range.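

In this assay, 2-(trifluoromethyl)pyrimidin-4-yl in place of pyridin-2-yl on an oxygen on a saturated carbon gives an at least 5.4-fold lower number from compound 3 to compound 4 (0.73 log units; beyond the scatter), a change at this position with a size beyond the scatter, whereas the earlier floors lay within it. The same oxygen-linked ring also compares favourably with both sulfur-linked groups, with an at least 5.4-fold lower number from compound 2 to compound 4 (0.73 log units; beyond the scatter) and a 2.8-fold lower number from compound 1 to compound 4 (0.44 log units; beyond the scatter), so a sulfanyl link is not required for a readable value here. Two of these steps are floors set by an assay limit, not full sizes: the limit of > 200000 nM in this assay, at which 2 of the 4 values shown sit.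

As far as these compounds go, the trifluoromethyl group and the second ring nitrogen enter together in compound 4, so their separate contributions remain open. Also open, from the compounds shown here alone, is whether an amine or a nitrile in place of the trifluoromethyl group would keep the value clear of the limit.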